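Title: Cyclohexyl-bearing chain replaces phenyl at the urea nitrogen

This account rests on a few compounds, and the source may have more. Where it says the series, first, only, none or still open, it means among the compounds named here.

Measured compounds:
compound 1 `Cc1nc(N)sc1CCCN/C(N)=N/C(=O)NCC(C)CCc1ccccc1` 63.1 nM
compound 2 `Cc1nc(N)sc1CCCN/C(N)=N/C(=O)NCc1ccccc1` 69.2 nM
compound 3 `Cc1nc(N)sc1CCCN/C(N)=N/C(=O)NC(c1ccccc1)c1ccccc1` 43.7 nM

In an assay on membranes from Sf9 cells for displacement of a labelled ligand from histamine H2 receptor (Homo sapiens), read by scintillation counting, with a stated time of 60 min (on this read-out higher numbers stand for weaker inhibition and lower numbers for stronger inhibition), compound 2 gives 69.2 nM, the highest of the three numbers, though every other compound lies within the scatter of it: compound 1 gives 63.1 nM and compound 3 gives 43.7 nM. The new compound 4 `Cc1nc(N)sc1CCCN/C(N)=N/C(=O)NCC(C)C1CCCCC1` differs from compound 2 by 1-cyclohexylethyl in place of phenyl on a saturated chain carbon bound to an amide-type nitrogen. Within the data shown here, only one measured step touches this position: a 1.6-fold lower number from compound 2 to compound 3 (0.20 log units; within the scatter), which did not move the number beyond the scatter. Compound 1, which carries a longer branched chain at the same nitrogen, also sits at a value indistinguishable from compound 2. Since neither a second phenyl nor a longer chain on this nitrogen shifted this assay beyond the scatter, the 1-cyclohexylethyl group is expected to leave the number near that of compound 2 as well, so compound 4 is estimated at 55 nM (range 20 nM to 150 nM). The expected step is therefore a 1.3-fold lower number from compound 2 to compound 4 (0.10 log units; within the scatter), within the scatter.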

Compound 4, inhibition constant: 39.8 nM
The estimate for compound 4 lay 1.4-fold (0.14 log units) above the measured number, and the stated range covers the measured number.
By their numbers in this assay, from the lowest: compounds 4, 3, 1 and 2 (each within the scatter of the next).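

In this assay the change from phenyl to 1-cyclohexylethyl on a saturated chain carbon bound to an amide-type nitrogen gives a 1.7-fold lower number from compound 2 to compound 4 (0.24 log units; within the scatter) and so stays within the scatter. Every earlier group at this place carried an aromatic ring, and compound 4 shows that a non-aromatic ring of carbon only does not take the number beyond the scatter either. Cyclohexyl in place of phenethyl on a saturated chain carbon bound to two saturated chain carbons gives a 1.6-fold lower number from compound 1 to compound 4 (0.20 log units; within the scatter) and also stays within the scatter.

The compounds shown leave open whether a group carrying an amine or a carboxylic acid at this place would take the number in this assay beyond the scatter. Nothing available bears on why the number stays within the scatter for these groups.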